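Heteroaryl Exchange on a Sulfonamide Nitrogen

A few compounds are considered here, and "the series" means these few. Any claim that something is new, unique, unknown or untested is made for them only; others in the source may bear on it.

Measured so far:
compound 1, `C=C1CC[C@@H]2[C@](C)(COC(C)=O)[C@H](OC(C)=O)CC[C@@]2(C)[C@H]1CC(Nc1ccc(S(=O)(=O)Nc2nccs2)cc1)C1=CCOC1=O`: 24800 nM
compound 2, `C=C1CC[C@@H]2[C@](C)(COC(C)=O)[C@H](OC(C)=O)CC[C@@]2(C)[C@H]1CC(Nc1ccc(S(=O)(=O)Nc2ccc(Cl)nn2)cc1)C1=CCOC1=O`: 5350 nM

Both were tested in a functional assay on NCI-H23 cells (Homo sapiens) for inhibition, read by sulforhodamine B assay, with a stated time of 48 h; a lower number here means a stronger inhibitor of growth, a higher number a weaker inhibitor of growth. Among the measured compounds shown here, compound 2 holds the lowest number of the two; the only measured step is a 4.6-fold lower number from compound 1 to compound 2 (0.67 log units; beyond the scatter), a change confined to the group on the sulfonamide nitrogen. Compound 3, `C=C1CC[C@@H]2[C@](C)(COC(C)=O)[C@H](OC(C)=O)CC[C@@]2(C)[C@H]1CC(Nc1ccc(S(=O)(=O)Nc2ncccn2)cc1)C1=CCOC1=O`, keeps the shared core and differs from compound 2 by pyrimidin-2-yl in place of 6-chloropyridazin-3-yl on a sulfonamide nitrogen. For the measured compounds named here, no measured step covers this exact exchange; the one known step, a 4.6-fold lower number from compound 1 to compound 2 (0.67 log units; beyond the scatter), shows only that a heteroaryl swap on this nitrogen moves the number by a modest amount, and there the 6-chloropyridazin-3-yl group entered while the number fell. With that group now leaving, a modest shift toward a higher number is expected for compound 3, a 2.1-fold higher number from compound 2 to compound 3 (0.31 log units; beyond the scatter). Compound 3 is therefore estimated at 11000 nM, within 3500 nM to 35000 nM.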

Compound 3, concentration for total growth inhibition: 5380 nM
Compound 3: middle estimate off by 2.0-fold (0.31 log units), on the high side, within the range that was stated.
By their numbers in this assay, from the lowest: compounds 2 and 3 (each within the scatter of the next); then compound 1.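

In this assay, the step from 6-chloropyridazin-3-yl to pyrimidin-2-yl on the sulfonamide nitrogen is a 1.0-fold higher number from compound 2 to compound 3 (0.00 log units; within the scatter), so at this position the chlorine-bearing group and a group without chlorine give numbers within the scatter of each other. Compound 3 also shows a 4.6-fold lower number from compound 1 to compound 3 (0.66 log units; beyond the scatter), close in size to a 4.6-fold lower number from compound 1 to compound 2 (0.67 log units; beyond the scatter), so the lower number relative to 1,3-thiazol-2-yl does not depend on 6-chloropyridazin-3-yl alone: both six-membered aromatic rings with 2 hetero atoms share it. No measurement shown here gives an explanation for this.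

The compounds shown leave open whether the ring hetero atoms matter at all, which a phenyl or pyridin-2-yl group on this nitrogen would address. They also leave open whether a chlorine on pyrimidin-2-yl or a methyl on 1,3-thiazol-2-yl would move the number.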